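The source may report more compounds than this note shows. Statements on the series, on what has been measured and on what is new or still open speak of the compounds shown alone.

Compound 1 `COc1ccc(-c2nc3sc(Cc4ccc(Cl)cc4)nn3c2Br)cc1` is, in an ADME assay on CCRF-CEM cells (Homo sapiens) for cytotoxicity, with a stated time of 72 h (on this read-out higher numbers stand for weaker inhibition and lower numbers for stronger inhibition), the compound with the lowest of the two numbers given, where compound 1 gives 58000 nM; compound 2 `Clc1ccc(Cc2nn3c(Br)c(-c4ccc(Cl)cc4Cl)nc3s2)cc1` gives 106000 nM in this assay, a difference that stays within the scatter. Compound 3 `O=[N+]([O-])c1ccc(-c2nc3sc(Cc4ccc(Cl)cc4)nn3c2Br)cc1` differs from compound 1 by nitro in place of methoxy on an aromatic carbon. Among the measured compounds shown here, the only measured step that bears on it, a 1.8-fold higher number from compound 1 to compound 2 (0.26 log units; within the scatter), reworks the same aryl group and stays within the scatter, so no step beyond the scatter is expected for compound 3. For compound 3 the expected value in this assay is 60000 nM, with a range from 20000 nM to 180000 nM, an expected step of a 1.0-fold higher number from compound 1 to compound 3 (0.01 log units; within the scatter).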

Compound 3, half-maximal inhibitory concentration: 73000 nM
Beside the measured number, compound 3's estimate is 1.2-fold (0.09 log units) below it; measured number inside the range.
By their numbers in this assay, from the lowest: compounds 1, 3 and 2 (each within the scatter of the next).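

In this assay, replacing methoxy with nitro para to a large group, with the rest of compound 1 unchanged, gives a 1.3-fold higher number from compound 1 to compound 3 (0.10 log units; within the scatter). This single-group swap at that ring carbon therefore gives no step beyond the scatter, which the earlier reworking of the whole aryl substitution could not show for one group alone. No measurement shown here offers an explanation for this result. The compounds shown leave open whether an amine or a carboxylic acid at this place would give a step beyond the scatter.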